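Replacing 2,4-dichlorophenyl with 4-methoxyphenyl

The compounds below may be only part of what the source reports. "The series", "measured", "known", "first", "only" and "open" are said of these compounds alone.

Measured in a functional assay on HL-60 cells (Homo sapiens) for antiproliferative activity, read by MTT assay, with a stated time of 72 h; on this read-out lower numbers stand for stronger inhibition and higher numbers for weaker inhibition:
- compound 1 `COc1cc(-n2ncnc2-c2ccc(C)cc2)cc(OC)c1OC`: 90 nM
- compound 2 `COc1cc(-c2ncnn2-c2ccc(Cl)cc2Cl)cc(OC)c1OC`: > 10000 nM (a limit)
- compound 3 `COc1cc(-n2ncnc2-c2ccc(Cl)cc2)cc(OC)c1OC`: > 10000 nM (a limit)

Compound 2 gives no number, only a limit. It sits at the limit of > 10000 nM in this assay, at which 2 of the 3 values shown sit. Its true position could lie anywhere on the far side of that limit, so any step away from it is poorly anchored.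

Compound 4 `COc1ccc(-n2ncnc2-c2cc(OC)c(OC)c(OC)c2)cc1` is the next to consider. The change is 4-methoxyphenyl in place of 2,4-dichlorophenyl on an aromatic nitrogen.

Going by the values given here, only one measured step bears on this, and it is large: an at least 110-fold higher number from compound 1 to compound 3 (2.04 log units; beyond the scatter). There, chloro in place of methyl on an aromatic carbon took the series from a number to a limit. Among these three compounds, the two carrying chloro give only a limit. Compound 1, without chloro, reaches 90 nM. Compound 4 also has no chloro, but its change sits on an aromatic nitrogen rather than an aromatic carbon, so the transfer is uncertain.

A large move to a lower number in this assay is therefore expected, with a real chance of no measurable gain. The expected change is an at least 33-fold lower number from compound 2 to compound 4 (1.52 log units; beyond the scatter). For compound 4 the estimated value is 300 nM, with an expected range of 30 nM to 5000 nM.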

Compound 4, half-maximal inhibitory concentration: 6200 nM
For compound 4 the middle estimate is 21-fold (1.32 log units) below the measured one, outside the stated range (above it).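

With 4-methoxyphenyl on the aromatic nitrogen, compound 4 gives a true number in this assay, 6200 nM, so this position of the series can now be read on a scale rather than only at the edge of the assay. The change reads as an at least 1.6-fold lower number from compound 2 to compound 4 (0.20 log units; that floor lies within the scatter), which means that a real gain from 4-methoxyphenyl in place of 2,4-dichlorophenyl is not established, although a larger step is not excluded. The step is anchored at one end only, and that end is a limit rather than a number: the limit of > 10000 nM in this assay, at which 2 of the 4 values shown sit.

Still open, going by these compounds, is whether the difference at this nitrogen follows from losing the two chloro groups or from gaining the methoxy group, a question that a plain phenyl or a 4-chlorophenyl in the same place would begin to separate. Also open, on these data alone, is how far this position accepts other groups on the ring, such as a 4-dimethylaminophenyl or a 4-hydroxyphenyl, and whether any of them would bring the value on this read-out well clear of the limit.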